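This account rests on a few compounds, and the source may have more. Where it says the series, first, only, none or still open, it means among the compounds named here.

Compound 1 `COc1ccc(-c2cnc(NC(=O)c3cnco3)n2C)cc1` and compound 2 `COc1ccc(-c2cnc(NC(=O)c3ccccc3)n2C)cc1` share the same core and differ only in the group attached to the carbonyl carbon. In a toxicity assay on THP-1 cells (Homo sapiens) for inhibition (a higher number here means that more compound is tolerated, a lower number that less compound is tolerated), compound 1 gives no number but a limit of the assay, > 100000 nM. In this assay compound 2 likewise gives only a limit, > 100000 nM. The step that the two limits leave unreadable from compound 1 to compound 2 therefore cannot be read in size, because of the limit of > 100000 nM in this assay, at which 2 of the 2 values shown sit. Compound 2 thus stands at the edge of what the assay can report, with no finite number behind it.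

Compound 3 `COc1ccc(-c2cnc(NC(=O)c3ccccc3Br)n2C)cc1` has not yet been measured in this assay. It differs from compound 2 in one place: bromo in place of hydrogen on an aromatic carbon. Within the data shown here, no measured step involves a bromo group, and the single measured step has no readable size, so the measured data give no direction for this change beyond the usual scatter. The expectation is that compound 3 remains close to the limit, with an estimated value of 100000 nM in this assay. This estimate means an expected step of a number no higher from compound 2 to compound 3 (the limit leaves the size open), taken as none beyond the scatter.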

Compound 3, half-maximal cytotoxic concentration: > 100000 nM
Compound 3: no number, only a limit; the forecaster's own chance of this, stated with the estimate: 65%; the middle value sits exactly at the limit.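

Compound 3 also gives only a limit in this assay, so neither its step from compound 2 nor its step from compound 1 can be read in size: the limit of > 100000 nM in this assay, at which 3 of the 3 values shown sit. The compounds shown leave open whether any change to the group on the carbonyl carbon would bring a finite number in this assay.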